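From benzyl to 4-chlorophenyl on the amide nitrogen

A few compounds are considered here, and "the series" means these few. Any claim that something is new, unique, unknown or untested is made for them only; others in the source may bear on it.

Compound 1 `CC(C)(C)NC(=O)CCc1cccc2c1B(O)OC2`: > 100000 nM
Compound 2 `O=C(CCc1cccc2c1B(O)OC2)NC1CCCCC1`: > 100000 nM
Compound 3 `O=C(CCc1cccc2c1B(O)OC2)NCc1ccccc1`: > 100000 nM

Three amides sharing one core were tested in a functional assay on MDA-MB-231 cells (Homo sapiens) for antiproliferative activity, read by MTT assay, with a stated time of 72 h (on this read-out higher numbers stand for weaker inhibition and lower numbers for stronger inhibition), and none of them gave a number. Compound 3 stands at a limit, > 100000 nM, and not at a measured value.

Compound 4 `O=C(CCc1cccc2c1B(O)OC2)Nc1ccc(Cl)cc1` differs from compound 3 only in the group on the nitrogen, with 4-chlorophenyl in place of benzyl on an amide-type nitrogen.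

The measured steps that bear on this change are swaps at that same nitrogen. They are a step that the two limits leave unreadable from compound 1 to compound 3 and a step that the two limits leave unreadable from compound 2 to compound 3. Neither has a size that can be read, and the same holds for a step that the two limits leave unreadable from compound 1 to compound 2.

For compound 3, with the limit of > 100000 nM in this assay, at which 3 of the 3 values shown sit, no step beyond the scatter is expected in this assay in either direction. The most likely report for compound 4 is that same limit again. The estimated step is a number no higher from compound 3 to compound 4 (the limit leaves the size open). For compound 4 the expected value is 100000 nM, with an estimated range from 30000 nM to 150000 nM.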

Compound 4, half-maximal inhibitory concentration: 3600 nM
Estimate against measurement, compound 4: 28-fold (1.44 log units) above, outside the stated range (below it).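

In this assay the amide nitrogen proves to be a place where the group can move the read-out: 4-chlorophenyl in place of benzyl gives an at least 27-fold lower number from compound 3 to compound 4 (1.44 log units; beyond the scatter), in place of cyclohexyl it gives an at least 27-fold lower number from compound 2 to compound 4 (1.44 log units; beyond the scatter), and in place of tert-butyl it gives an at least 27-fold lower number from compound 1 to compound 4 (1.44 log units; beyond the scatter). The steps among the three earlier compounds cannot be read, so those compounds showed no effect of this group at all, and the present change shows one even though benzyl and 4-chlorophenyl have the same count of heavy atoms, one six-membered aromatic ring each, and no hydrogen-bond donors or acceptors. Compound 4 is the only compound here with a measured number, and all the others stay at a limit: the limit of > 100000 nM in this assay, at which 3 of the 4 values shown sit.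

The change from benzyl to 4-chlorophenyl brings in chlorine and also puts the aromatic ring directly on the amide nitrogen, so the compounds shown cannot say which of the two carries the step; phenyl or 4-chlorobenzyl on the same nitrogen would separate them. From the compounds shown here alone, how the value responds to another group in place of the chlorine, such as fluorine, methoxy or trifluoromethyl, also stays open.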